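The compounds below may be only part of what the source reports. "The series", "measured", "known", "first", "only" and "open" are said of these compounds alone.

Working notes on the series. In a functional assay on HCT-116 cells (Homo sapiens) for antiproliferative activity, read by sulforhodamine B assay, with a stated time of 72 h (on this read-out higher numbers stand for weaker inhibition and lower numbers for stronger inhibition), compound 1 (`Cc1ccc(N2CCN(c3ncnc4c3ncn4[C@@H]3O[C@H](CO)[C@@H](O)[C@H]3O)CC2)cc1`) gives 70000 nM. Compound 2 (`Nc1nc(N2CCN(c3ncccn3)CC2)c2ncn([C@@H]3O[C@H](CO)[C@@H](O)[C@H]3O)c2n1`) is reported as "not active" (no number reported), with no number attached. Compound 3 (`Nc1nc(N2CCN(c3ccccc3)CC2)c2ncn([C@@H]3O[C@H](CO)[C@@H](O)[C@H]3O)c2n1`) gives 30000 nM, the lower of the two numbers available, and its gap to compound 1 lies beyond the scatter.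

Next comes compound 4 (`Cc1ccc(N2CCN(c3nc(N)nc4c3ncn4[C@@H]3O[C@H](CO)[C@@H](O)[C@H]3O)CC2)cc1`), which differs from compound 3 in one place: methyl in place of hydrogen on an aromatic carbon. This is methyl in place of hydrogen on an aromatic carbon, so phenyl becomes 4-methylphenyl. Going by the values given here, no measured pair isolates a single change, so this one has no direct precedent. The core of compound 3 differs from that of compound 1, which carries the 4-methylphenyl group and gives 70000 nM, so that comparison offers only loose guidance.

In this assay no step beyond the scatter is expected, with at most a slight upward drift in the number. The estimated step is a 1.2-fold higher number from compound 3 to compound 4 (0.07 log units; within the scatter). A report without a number remains possible, as seen for compound 2. For compound 4 the estimated value is 35000 nM, with an expected range from 12000 nM to 90000 nM.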

Compound 4, half-maximal inhibitory concentration: "not active" (no number reported)
The entry for compound 4 holds no number; no gap can be computed for the estimate.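

Going by these compounds alone, compound 4 is reported as "not active" in this assay with no number attached, so no step from compound 3 to compound 4 can be read. Nothing measured here offers an explanation for this result. Left open is what the change from phenyl to 4-methylphenyl does numerically, as no pair shown differs in one place with numbers on both sides.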